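Alkene geometry switch in a phenoxyacetic acid series

A few compounds are considered here, and "the series" means these few. Any claim that something is new, unique, unknown or untested is made for them only; others in the source may bear on it.

Of the compounds shown here, two have been measured in an assay for displacement of a labelled ligand from prostacyclin receptor (Homo sapiens); on this read-out lower numbers stand for stronger inhibition and higher numbers for weaker inhibition. Compound 1 `O=C(O)COc1cccc2c1CCC(C/C=C/CC(c1ccccc1)c1ccccc1)C2` gives 3100 nM. Compound 2 `O=C(O)COc1cccc2c1CCC(C/C=C/C(O)Cc1ccccc1)C2` gives 4900 nM in this assay; the two numbers lie within the usual scatter of each other, so neither stands apart. Compound 3 `O=C(O)COc1cccc2c1CCC(C/C=C\CC(c1ccccc1)c1ccccc1)C2` differs from compound 1 only in alkene geometry: the two compounds have the same atoms and bonds; at least one stereo element is drawn with a configuration in one of them and without one in the other: 1 of 2 stereo elements differ; a double bond is drawn E in compound 1 and Z in compound 3. Among the compounds with values here, no measured pair shows what such a geometry change does here, so no direction can be read from the data. The expected step of a 1.3-fold higher number from compound 1 to compound 3 (0.11 log units; within the scatter) is therefore set close to nothing beyond the scatter, with wide bounds. Compound 3 is estimated at 4000 nM in this assay, with a range from 1500 nM to 12000 nM.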

Compound 3, half-maximal inhibitory concentration: 3000 nM
For compound 3 the middle estimate is 1.3-fold (0.12 log units) above the measured one; measured number inside the range.
By their numbers in this assay, from the lowest: compounds 3, 1 and 2 (each within the scatter of the next).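

In this assay, within the data shown here, the double bond drawn E and then Z gives a 1.0-fold lower number from compound 1 to compound 3 (0.01 log units; within the scatter), the first measured pair for this change. At this position in this chain, the assay therefore does not separate the two geometries. One caveat applies to this reading: the fact that one of compounds 1 and 3 is drawn with a defined configuration and the other without, at the place where they differ

Still open, on these data alone, is whether the same holds for the hydroxyl-bearing chain of compound 2. Also open, as far as these compounds go, is what a fully saturated chain in place of the double bond, or an amide in place of the carboxylic acid, would give.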